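The source may report more compounds than this note shows. Statements on the series, on what has been measured and on what is new or still open speak of the compounds shown alone.

Compound 1 `CC(C)CCn1nc(C2=CCCC2)c(O)c(C2=NS(=O)(=O)c3cc(NS(C)(=O)=O)ccc3N2)c1=O`: > 1000 nM.
Compound 2 `CC(C)CCc1nn(CCC(C)C)c(=O)c(C2=NS(=O)(=O)c3cc(NS(C)(=O)=O)ccc3N2)c1O`: > 33000 nM.
Compound 3 `COC(C)(C)CCn1nc(-c2cccs2)c(O)c(C2=NS(=O)(=O)c3cc(NS(C)(=O)=O)ccc3N2)c1=O`: > 33000 nM.

In an ADME assay on Huh-7 cells (Homo sapiens) for cytotoxicity, with a stated time of 72 h (a higher number here means that more compound is tolerated, a lower number that less compound is tolerated), compound 1 gives > 1000 nM, which is a limit of the assay and not a number. Compound 2 gives > 33000 nM, also a limit. Compound 3 gives > 33000 nM, again a limit, so it rests at the limit of > 33000 nM in this assay, at which 2 of the 3 values shown sit, where two of the three values sit. Within the data shown here, the single measured step, a step that the two limits leave unreadable from compound 1 to compound 2, is left unreadable by the two limits. Compound 4 `CS(=O)(=O)Nc1ccc2c(c1)S(=O)(=O)N=C(c1c(O)c(-c3cccs3)nn(CCC3CCCCC3)c1=O)N2` differs from compound 3 by cyclohexyl in place of 1-methoxy-1-methylethyl on a saturated chain carbon, two bonds along the chain from an aromatic nitrogen. No readable measured step bears on this change, and compound 3 itself shows only a limit, so no size or direction of step can be drawn from the data. Compound 4 is expected to stay close, with an estimated step that the limit leaves unreadable from compound 3 to compound 4. In this assay compound 4 is estimated at 40000 nM, ranging from 12000 nM to 120000 nM.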

Compound 4, half-maximal cytotoxic concentration: > 17000 nM
Compound 4 ended at the assay's limit; the forecaster's own chance of this, stated with the estimate: 75%; the middle value is on the limit's open side.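

Among these compounds, compound 3 and compound 4 both rest on limits, so no step between them can be read. The compounds shown leave open whether cyclohexyl in place of 1-methoxy-1-methylethyl changes the tolerated concentration in this assay at all.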